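Swapping a Terminal Amine for a Longer Hydroxyl Chain

This account rests on a few compounds, and the source may have more. Where it says the series, first, only, none or still open, it means among the compounds named here.

Measured so far:
compound 1, `NCCCCCCOc1ccc2c(=O)c(-c3ccc(O)cc3)coc2c1`: 100 nM
compound 2, `O=C(O)COc1ccc(-c2coc3cc(OCC(=O)O)ccc3c2=O)cc1`: >> 9000 nM

Among the compounds with values here, in an assay (Cricetulus griseus) for inhibition of aldehyde dehydrogenase, mitochondrial (Homo sapiens) (a lower number here means a stronger inhibitor, a higher number a weaker inhibitor), compound 1 gives 100 nM, the only plain number in this set. For compound 2 the assay reports just a limit, >> 9000 nM, so compound 1 stands alone as a measured reference.

Compound 3 `O=c1c(-c2ccc(O)cc2)coc2cc(OCCCCCCCCCCCCO)ccc12` differs from compound 1 by 6-hydroxyhexyl in place of amino on a saturated chain carbon, six bonds along the chain from an oxygen on an aromatic ring. Within the data shown here, no measured step exists between any two compounds here, so the expectation rests on the change alone: a modest loss of potency, somewhat beyond the scatter, is expected as a 3.0-fold higher number from compound 1 to compound 3 (0.48 log units; beyond the scatter). Compound 3 is therefore estimated at 300 nM, most likely between 60 nM and 2000 nM.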

Compound 3, half-maximal inhibitory concentration: 1700 nM
Beside the measured number, compound 3's estimate is 5.7-fold (0.75 log units) below it, within the range that was stated.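

In this assay the chain end of compound 1 proves sensitive: 6-hydroxyhexyl in place of amino gives a 17-fold higher number from compound 1 to compound 3 (1.23 log units; beyond the scatter) and still leaves a plain number rather than a limit. Potency therefore responds strongly to this change, yet inhibition is not lost. Nothing shown accounts for the size of this loss.

Going by these compounds, the step swaps the amino group and lengthens the chain at once, so the share of each stays open. A hydroxyl group on the shorter chain of compound 1, or an amine on the longer chain of compound 3, would separate the two.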